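Branching the thioether: isopropylsulfanyl to tert-butylsulfanyl

The compounds below may be only part of what the source reports. "The series", "measured", "known", "first", "only" and "open" are said of these compounds alone.

Compound 1, `CCC(C)c1cc(C)c(C(=O)N=C(N)N)cc1S(C)(=O)=O`, in a functional assay for inhibition of sodium/hydrogen exchanger (Oryctolagus cuniculus); on this read-out higher numbers stand for weaker inhibition and lower numbers for stronger inhibition: 8 nM
Compound 2, `Cc1cc(SC(C)C)c(S(C)(=O)=O)cc1C(=O)N=C(N)N`, in this assay: 12 nM

Within the data shown here, compound 2 carries the higher of the two numbers so far in this assay, but its only neighbour is compound 1, and the step of a 1.5-fold higher number from compound 1 to compound 2 (0.18 log units; within the scatter) lies within the scatter, so the two compounds cannot be told apart on these data. Compound 3, `Cc1cc(SC(C)(C)C)c(S(C)(=O)=O)cc1C(=O)N=C(N)N`, is the next compound along this line. It differs from compound 2 by methyl in place of hydrogen on a saturated chain carbon bound to two saturated chain carbons and a sulfur. Among the measured compounds shown here, the single measured step, a 1.5-fold higher number from compound 1 to compound 2 (0.18 log units; within the scatter), exchanges one branched chain for another at the same position of the shared core and does not move the number beyond the scatter; no measured pair shows what adding a methyl to the chain carbon bound to the sulfur does. For the measured compounds named here, with that as the only guide, compound 3 is expected to stay close to compound 2 in this assay, with a step of a 1.3-fold higher number from compound 2 to compound 3 (0.10 log units; within the scatter) that is most likely within the scatter. Compound 3 is therefore estimated at 15 nM in this assay, with a range from 6 nM to 40 nM.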

Compound 3, half-maximal inhibitory concentration: 22 nM
Compound 3: middle estimate off by 1.5-fold (0.17 log units), on the low side; low and high end bracket the measured number.
By their numbers in this assay, from the lowest: compounds 1, 2 and 3 (each within the scatter of the next, the first and the last beyond it).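

In this assay, among these compounds, the methyl that turns isopropylsulfanyl into (tert-butyl)sulfanyl gives a 1.8-fold higher number from compound 2 to compound 3 (0.26 log units; within the scatter) and so leaves compound 2 and compound 3 indistinguishable, which is the first reading of a change on the chain carbon bound to the sulfur. Among the compounds shown here, the comparison with the sec-butyl compound does separate, with a 2.8-fold higher number from compound 1 to compound 3 (0.44 log units; beyond the scatter) as the first step in this assay to pass the scatter, so the group on this aromatic carbon has now been seen to shift the number, though only by a small margin and only across the two ends of the order, while each neighbouring pair still overlaps. Nothing available accounts for this shift or says what lies behind it.

The compounds shown leave open how far this aromatic carbon accepts groups of another kind, such as an amine, a carboxylic acid or a longer chain like n-hexyl. They also leave open whether the sulfur itself counts, which isopropoxy or plain isopropyl in place of isopropylsulfanyl would address.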